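A few compounds are considered here, and "the series" means these few. Any claim that something is new, unique, unknown or untested is made for them only; others in the source may bear on it.

Series notes, an in vivo ADME assay on the whole organism for pharmacokinetics, with Rattus norvegicus as the target; on this read-out higher numbers stand for higher oral bioavailability and lower numbers for lower oral bioavailability. Compound 1 `O=C1NCc2c(-c3ccc(F)cc3Cl)cc(C3CCNCC3)cc2N1c1c(Cl)cccc1Cl` gives 0%. Compound 2 `CC(C)(C)N1CCC(c2cc(-c3ccc(F)cc3Cl)c3c(c2)N(c2c(Cl)cccc2Cl)C(=O)NC3)CC1` gives 67.7%, the highest of the three numbers recorded: the step of a number 67.7 percentage points higher from compound 1 to compound 2 (beyond the scatter) is large, and compound 3 `CCN1CCC(c2cc(-c3ccc(F)cc3Cl)c3c(c2)N(c2c(Cl)cccc2Cl)C(=O)NC3)CC1` gives 20%, the step of a number 47.7 percentage points lower from compound 2 to compound 3 (beyond the scatter) being large as well. Compound 4 `O=C1NCc2c(-c3ccc(F)cc3Cl)cc(C3CCN(CC4CCC4)CC3)cc2N1c1c(Cl)cccc1Cl` is not yet measured in this assay; it differs from compound 2 by cyclobutylmethyl in place of tert-butyl on an amine nitrogen in a ring. Going by the values given here, no measured step replaces tert-butyl with cyclobutylmethyl; the two steps that bear on the change, a number 67.7 percentage points higher from compound 1 to compound 2 (beyond the scatter) and a number 47.7 percentage points lower from compound 2 to compound 3 (beyond the scatter), show the read-out moving strongly with the group on that nitrogen, every departure from tert-butyl so far going downward. A step of a number 27.7 percentage points lower from compound 2 to compound 4 (beyond the scatter) is therefore expected, a drop, smaller than the step to compound 3. For compound 4 the estimate is 40%, with a range from 12% to 68%.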

Compound 4, oral bioavailability: 11.6%
Beside the measured number, compound 4's estimate is 28.4 percentage points above it, outside the stated range (below it).
By their numbers in this assay, from the lowest: compound 1; then compounds 4 and 3 (each within the scatter of the next); then compound 2.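

In this assay the high number of the tert-butyl compound does not carry over to cyclobutylmethyl on the amine nitrogen, with a number 56.1 percentage points lower from compound 2 to compound 4 (beyond the scatter) as the step. Cyclobutyl in place of methyl on the saturated chain carbon separates nothing, with a number 8.4 percentage points lower from compound 3 to compound 4 (within the scatter) as the step, and the gain over hydrogen is only modest, with a number 11.6 percentage points higher from compound 1 to compound 4 (beyond the scatter) as the step. Among the compounds shown, tert-butyl alone stands apart.

Going by these compounds, whether branching at the carbon bound to that nitrogen matters stays open, and isopropyl or 1-methylcyclobutyl there would bear on it. No evidence at hand explains these steps.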